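The source may hold more compounds than are shown below. What is called first, only, known or untested is meant among the compounds shown, and "the series" means these compounds.

In an ADME assay on Akata cells (Homo sapiens) for cytotoxicity, with a stated time of 7 days (a higher number here means that more compound is tolerated, a lower number that less compound is tolerated), the three measured compounds give only limits of the assay, not numbers:
compound 1 `CNc1nc(N)nc2c1ncn2/C=C1/CC1(CO)CO`: > 24000 nM.
compound 2 `Nc1nc(OCc2ccccc2)c2ncn(/C=C3/CC3(CO)CO)c2n1`: > 20000 nM.
compound 3 `Nc1nc2c(ncn2/C=C2/CC2(CO)CO)c(=O)[nH]1`: > 20000 nM.

Among the measured compounds shown here, compound 2 therefore stands at a limit, as do the other two measured compounds the limit of > 20000 nM in this assay, at which 2 of the 3 values shown sit (the limit of > 24000 nM in this assay, at which 1 of the 3 values shown sits), so no measured compound can be ranked against another. The unmeasured compound 4 `CSc1nc(N)nc2c1ncn2/C=C1/CC1(CO)CO` differs from compound 2 in one place: methylsulfanyl in place of benzyloxy on an aromatic carbon. For the measured compounds named here, the only measured step that touches compound 2 is a step that the two limits leave unreadable from compound 1 to compound 2, and its size cannot be read. So no measured step shows how this assay answers a change at that position, and no step beyond the scatter is expected here. Compound 4 is estimated at 22000 nM, between 8000 nM and 50000 nM, most likely again as a limit. The step from compound 2 to compound 4 is thus expected to be a step that the limit leaves unreadable from compound 2 to compound 4.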

Compound 4, half-maximal cytotoxic concentration: > 20000 nM
Compound 4: a limit, no number (the forecaster's own chance of this, stated with the estimate: 80%); the middle value is on the limit's open side.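

Compound 4 also gives only a limit, as do compound 1 and compound 2, and the steps among these three compounds cannot be read. What the compounds shown leave open is whether changing the group on that aromatic carbon matters at all in this assay.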